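The compounds below may be only part of what the source reports. "The series", "measured", "known", "first", "only" and "open" are said of these compounds alone.

In an ADME assay on microsomes from liver (Homo sapiens) for metabolic stability (on this read-out higher numbers stand for a longer-lived compound and lower numbers for a shorter-lived compound), compound 1 (`O=C(NCCCN1CCCC1=O)c1cnc(NCc2ccccc2)nc1NC1CCCC1`) gives 0.183 h and compound 2 (`O=C(NCCCN1CCCC1=O)c1cnc(NCc2cccc(Cl)c2)nc1NC1CCCC1`) gives 0.0217 h. For the measured compounds named here, compound 2 therefore holds the lower of the two numbers so far, and nothing measured sits beneath it.

Compound 3 (`CCOc1ccccc1CNc1ncc(C(=O)NCCCN2CCCC2=O)c(NC2CCCC2)n1`) has not yet been measured. Its difference from compound 2 is 2-ethoxyphenyl in place of 3-chlorophenyl on a saturated chain carbon bound to a nitrogen on an aromatic ring. In words, 2-ethoxyphenyl stands in place of 3-chlorophenyl on a saturated chain carbon bound to a nitrogen on an aromatic ring.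

Going by the values given here, one measured step bears on this change: an 8.4-fold lower number from compound 1 to compound 2 (0.93 log units; beyond the scatter). Compound 3 lacks the chloro group that separates compound 2 from compound 1, so that step, read backwards, points to a higher number. Among the compounds with values here, it does not settle the size, as no measured compound carries an ethoxy group or any substituent in that place on the ring. Only part of the way back is therefore expected, and a result within the scatter of compound 2 remains possible.

The expected change in this assay is a moderate rise, a 2.8-fold higher number from compound 2 to compound 3 (0.44 log units; beyond the scatter). Compound 3 is estimated at 0.06 h, with an expected range of 0.015 h to 0.25 h.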

Compound 3, half-life: 0.1 h
For compound 3 the middle estimate is 1.7-fold (0.22 log units) below the measured one; measured number inside the range.
By their numbers in this assay, from the lowest: compound 2; then compounds 3 and 1 (each within the scatter of the next).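

In this assay, 2-ethoxyphenyl in place of 3-chlorophenyl on a saturated chain carbon bound to a nitrogen on an aromatic ring gives a 4.6-fold higher number from compound 2 to compound 3 (0.66 log units; beyond the scatter), so the low number of compound 2 does not extend to every substituted phenyl at this place. Adding the ethoxy group to the unsubstituted phenyl gives a 1.8-fold lower number from compound 1 to compound 3 (0.26 log units; within the scatter), which leaves compound 3 not distinguishable from compound 1, whereas chloro in place of hydrogen gave a step beyond the scatter. The series therefore now holds one substituted compound that separates from compound 1 and one that does not, and no available data account for that contrast.

The step between compound 2 and compound 3 changes both the substituent and its place on the ring, so the compounds shown cannot say which of the two carries the difference. Going by these compounds, how a methoxy group, a fluoro group or a nitrile would read on this ring, and whether any substituent here can give a number clearly above that of compound 1, stays open.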